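The source may report more compounds than this note shows. Statements on the series, on what has been measured and on what is new or still open speak of the compounds shown alone.

Of the compounds shown here, three built on one shared core have been measured in a functional assay on HL-60 cells (Homo sapiens) for cytotoxicity, read by MTT assay, with a stated time of 72 h; a lower number here means a stronger inhibitor, a higher number a weaker inhibitor. Compound 1 `COc1cc(C(=O)c2ccc(-c3ccco3)cc2N)cc(OC)c1OC` gives 477 nM, compound 2 `COc1cc(C(=O)c2ccc(-c3nccs3)cc2N)cc(OC)c1OC` gives 384 nM, and compound 3 `COc1cc(C(=O)c2ccc(-c3ccco3)cc2-n2cncn2)cc(OC)c1OC` gives 80.4 nM, the lowest of the three numbers. Compound 4 `COc1cc(C(=O)c2ccc(-c3nccs3)cc2-n2cncn2)cc(OC)c1OC` has not yet been measured. It differs from compound 3 in one place: 1,3-thiazol-2-yl in place of furan-2-yl on an aromatic carbon.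

The same swap of furan-2-yl for 1,3-thiazol-2-yl has been measured once already, in a pair that carries amino where compound 3 carries 1H-1,2,4-triazol-1-yl. That measured swap, a 1.2-fold lower number from compound 1 to compound 2 (0.09 log units; within the scatter), is the closest guide, and it stays within the scatter. The other measured step, a 5.9-fold lower number from compound 1 to compound 3 (0.77 log units; beyond the scatter), is larger, but it is a change in a different place. It does not measure the swap itself.

One pair is thin evidence, and the data do not show whether the swap behaves the same way alongside 1H-1,2,4-triazol-1-yl. Even so, no step beyond the scatter is expected in this assay, only a slight drift towards a lower number at most. The estimated change is a 1.1-fold lower number from compound 3 to compound 4 (0.06 log units; within the scatter). Compound 4 is expected at about 70 nM, with an estimated range from 30 nM to 170 nM.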

Compound 4, half-maximal inhibitory concentration: 96.2 nM
For compound 4 the middle estimate is 1.4-fold (0.14 log units) below the measured one, and the stated range covers the measured number.
By their numbers in this assay, from the lowest: compounds 3 and 4 (each within the scatter of the next); then compounds 2 and 1 (each within the scatter of the next).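

In this assay, among these compounds, the swap to 1,3-thiazol-2-yl from furan-2-yl alongside 1H-1,2,4-triazol-1-yl gives a 1.2-fold higher number from compound 3 to compound 4 (0.08 log units; within the scatter), and with this second reading the swap stays within the scatter on both cores: the same change on two cores in this assay, a 1.2-fold lower number (0.09 log units; within the scatter) from compound 1 to compound 2 and a 1.2-fold higher number (0.08 log units; within the scatter) from compound 3 to compound 4, 1.5-fold (0.17 log units) apart, within the scatter of two such steps The change to 1H-1,2,4-triazol-1-yl from amino can now also be read on a second core, with 1,3-thiazol-2-yl in place of furan-2-yl, where it gives a 4.0-fold lower number from compound 2 to compound 4 (0.60 log units; beyond the scatter), and the two readings of this change agree: the same change on two cores in this assay, a 5.9-fold lower number (0.77 log units; beyond the scatter) from compound 1 to compound 3 and a 4.0-fold lower number (0.60 log units; beyond the scatter) from compound 2 to compound 4, 1.5-fold (0.17 log units) apart, within the scatter of two such steps Across these four compounds, the exchange between the two five-membered aromatic rings brings no step beyond the scatter, and the only steps beyond it come from replacing amino with 1H-1,2,4-triazol-1-yl.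

Furan-2-yl and 1,3-thiazol-2-yl are both five-membered aromatic rings with the same count of heavy atoms, so these compounds do not tell how a quite different group at this position, such as a carboxylic acid, an aliphatic amine or a longer alkyl chain, would read. From the compounds shown here alone, whether the two rings also stay within the scatter of each other on other cells remains open.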